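This account rests on a few compounds, and the source may have more. Where it says the series, first, only, none or still open, it means among the compounds named here.

Compound 1 `O=C1COc2ccc(-c3cnc(Cl)c(NS(=O)(=O)c4ccc(F)cc4)c3)cc2N1C1CCCCC1`: 14300 nM
Compound 2 `COc1ncc(-c2ccc3c(c2)N(c2ccc(F)cc2)C(=O)CO3)cc1NS(=O)(=O)c1ccc(F)cc1`: 10500 nM

Both compounds were tested in a functional assay on HeLa cells (Homo sapiens) for antiproliferative activity, read by MTT assay, with a stated time of 72 h; on this read-out lower numbers stand for stronger inhibition and higher numbers for weaker inhibition. Going by the values given here, their two values lie within the usual scatter of each other, so compound 2 cannot be placed ahead of or behind compound 1, the only other compound measured so far.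

Compound 3 `O=C1COc2ccc(-c3cnc(Cl)c(NS(=O)(=O)c4ccc(F)cc4)c3)cc2N1c1ccc(F)cc1` has not yet been measured. It is compound 2 with chloro in place of methoxy on an aromatic carbon, next to the ring nitrogen and ortho to a ((4-fluorophenyl)sulfonyl)amino group (chloro in place of methoxy on an aromatic carbon). Among the compounds with values here, no measured pair shows this change alone, so the evidence is thin. Compound 1, which also carries chloro, gives 14300 nM, and compound 2, with methoxy, gives 10500 nM. On these values, no change beyond the scatter is expected in this assay. The expected change is a 1.0-fold higher number from compound 2 to compound 3 (0.02 log units; within the scatter). For compound 3 the estimate is 11000 nM, with an expected range of 4500 nM to 27000 nM.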

Compound 3, half-maximal inhibitory concentration: > 40000 nM
Compound 3: only a limit was reported; the forecaster's own chance of this, stated with the estimate: 10%; middle value at least 3.6-fold (0.56 log units) from the limit.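

In this assay compound 3 gives > 40000 nM, which is a limit of the assay and not a number. Chloro in place of methoxy, as the only change, brings an at least 3.8-fold higher number from compound 2 to compound 3 (0.58 log units; beyond the scatter), so with a 4-fluorophenyl group on the ring nitrogen of the amide, this aromatic carbon is sensitive to the swap, something compound 1 and compound 2 could not show, since they differ in two places. The other single change, 4-fluorophenyl in place of cyclohexyl on that amide-type nitrogen, brings an at least 2.7-fold higher number from compound 1 to compound 3 (0.44 log units; beyond the scatter), so with chloro present, the group on that nitrogen matters as well.

From the compounds shown here alone, with only a limit for compound 3, the true size of both steps stays open. Also open, going by these compounds, is whether an amine or an ethoxy group on this carbon would behave like methoxy or like chloro.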